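The source may hold more compounds than are shown below. What is called first, only, known or untested is meant among the compounds shown, and "the series" means these compounds.

Measured so far in a functional assay on HeLa cells (Homo sapiens) for inhibition; a lower number here means a stronger inhibitor, a higher number a weaker inhibitor:
compound 1, `Oc1ccc(-c2cc(-c3cccc(C(F)(F)F)c3)cc(-c3ccc(O)cc3)n2)cc1`: > 50000 nM
compound 2, `Oc1ccc(-c2cc(-c3cccc(OC(F)(F)F)c3)cc(-c3cccc(O)c3)n2)cc1`: 14100 nM

In this assay compound 2 gives 14100 nM. For compound 1 the assay reports only a limit, > 50000 nM, which is the limit of > 50000 nM in this assay, at which 1 of the 2 values shown sits. Within the data shown here, compound 2 therefore stands as the sole numbered value in this assay; the other entry is a limit and not a number, so no order between the two can be stated.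

Compound 3, `Oc1ccc(-c2cc(-c3cccc(OC(F)(F)F)c3)cc(-c3ccc(O)cc3)n2)cc1`, has not been measured in this assay. It differs from compound 2 in one place: 4-hydroxyphenyl in place of 3-hydroxyphenyl on an aromatic carbon. Among the measured compounds shown here, no measured pair shows this change by itself, so its size is not known from the data. Compound 1 also carries two 4-hydroxyphenyl groups on the shared core and sits at the limit, while compound 2, with one 3-hydroxyphenyl, gives a number; with compound 1 and compound 2 differing in a second place as well, this is a hint only. The expected step in this assay is a 2.1-fold higher number from compound 2 to compound 3 (0.33 log units; beyond the scatter), toward weaker inhibition, likely beyond the scatter. Compound 3 is estimated at 30000 nM, within a range from 10000 nM to 100000 nM, and a limit rather than a number is a real possibility.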

Compound 3, half-maximal inhibitory concentration: > 50000 nM
Compound 3: no number, only a limit; the forecaster's own chance of this, stated with the estimate: 40%; middle value at least 1.6-fold (0.22 log units) away from the limit.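

In this assay, placing 4-hydroxyphenyl in place of 3-hydroxyphenyl next to the ring nitrogen, with the trifluoromethoxy group held constant, gives an at least 3.5-fold higher number from compound 2 to compound 3 (0.54 log units; beyond the scatter), so this change now has a measured lower bound in an isolated pair. The entry for compound 3 is a limit of the assay and not a number, which leaves the upper end of the step open. Within this set, a numbered value occurs only with 3-hydroxyphenyl at this position, in compound 2, while compound 1 and compound 3, both with 4-hydroxyphenyl there, give no number: the limit of > 50000 nM in this assay, at which 2 of the 3 values shown sit.

The change from trifluoromethyl to trifluoromethoxy between compound 1 and compound 3 cannot be read, as both entries are limits, so the contribution of that group remains unresolved, and it could only be read on a background that gives numbers, such as the 3-hydroxyphenyl one. Also open, from the compounds shown here alone, is how far the hydroxyl itself matters at this position, which an aminophenyl or methoxyphenyl group in place of 3-hydroxyphenyl would address.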